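The compounds below may be only part of what the source reports. "The series", "measured", "known", "first", "only" and "open" are said of these compounds alone.

Compound 1 `CCCOC(=O)C1=C(C)NC(=O)NC1c1ccoc1` gives 11% in an assay on membranes from HeLa cells for displacement of a labelled ligand from adenosine receptor A3 (Homo sapiens), read by scintillation counting, with a stated time of 180 min, tested at 1 uM; a lower number here means less inhibition, a higher number more inhibition at the concentration tested (going by the name of the read-out). Compound 2 `CC1=C(C(=O)OCC(C)C)C(c2ccoc2)NC(=O)N1` gives 16% in this assay; the step of a number 5 percentage points higher from compound 1 to compound 2 (within the scatter) accompanies (methyl in place of hydrogen on a saturated chain carbon bound to two saturated chain carbons). Compound 3 `CCSC(=O)C1=C(C)NC(=O)NC1c1ccco1` gives 14% in this assay; the difference between the core of compound 1 and the core of compound 3 is not broken down here. Compound 4 `CC1=C(C(=O)SC(C)C)C(c2ccco2)NC(=O)N1` awaits measurement in this assay. Among the measured compounds shown here, it differs from compound 3 by methyl in place of hydrogen on a saturated chain carbon bound to a saturated chain carbon and a sulfur, the same kind of change as the one between compound 1 and compound 2, though here the carbon carrying the new methyl is bound to a saturated chain carbon and a sulfur rather than to two saturated chain carbons. Compound 4 is expected to show a step of a number 3 percentage points higher from compound 3 to compound 4 (within the scatter) in this assay, of similar size to the earlier step, because a number 5 percentage points higher from compound 1 to compound 2 (within the scatter) lies within the scatter. Compound 4 is expected at 17% in this assay, between 5% and 30%.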

Compound 4, a percentage reported as inhibition, at one concentration (the size of the read-out at that concentration, not a potency): 1%
Compound 4: the middle estimate sits 16 percentage points above what was measured; the measured number lies below the stated range.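

In this assay the new step is a number 13 percentage points lower from compound 3 to compound 4 (beyond the scatter), so methyl in place of hydrogen does not carry over from the core of compound 1 to the core of compound 3 with a similar effect: the same change on two cores in this assay, a number 5 percentage points higher (within the scatter) from compound 1 to compound 2 and a number 13 percentage points lower (beyond the scatter) from compound 3 to compound 4, 18 percentage points apart, beyond the scatter of two such steps This rests on a single pair for each core, and these readings at one concentration are not potencies. It does not show which difference between the cores goes with the gap, nor whether the drop seen with (isopropylsulfanyl)carbonyl would recur on other cores.

The compounds shown leave open how a longer chain, such as butylsulfanyl in place of isopropylsulfanyl, would read. Also open, on these data alone, is whether an amine-bearing chain in that place would follow compound 3 or compound 4.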